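Shrinking the amine on the side chain of compound 2

This account rests on a few compounds, and the source may have more. Where it says the series, first, only, none or still open, it means among the compounds named here.

compound 1, `CCN(CC)CN1C(=O)/C(=N\c2nc3ccc(C)cc3s2)c2ccccc21`: in an ADME assay on 184B5 cells (Homo sapiens) for cytotoxicity, read by sulforhodamine B assay, with a stated time of 48 h (a lower number here means a stronger inhibitor of growth, a higher number a weaker inhibitor of growth), compound 1 gives 27500 nM.
compound 2, `Cc1ccc2nc(/N=C3\C(=O)N(CN4CCCCC4)c4ccccc43)sc2c1`: in this assay compound 2 gives 34900 nM.
compound 3, `O=C1C(=O)N(CN(c2ccccc2)c2ccccc2)c2ccccc21`: in this assay compound 3 gives 33700 nM.

Compound 2 sits level with compound 1 and compound 3: the three numbers lie within the usual scatter of one another, so none of them can be called a stronger or weaker inhibitor of growth than the others. Compound 4, `Cc1ccc2nc(/N=C3\C(=O)N(CN(C)C)c4ccccc43)sc2c1`, differs from compound 2 in a single place: dimethylamino in place of piperidin-1-yl on a saturated chain carbon bound to an amide-type nitrogen in a ring. Within the data shown here, the one measured step that bears on this place is a 1.3-fold higher number from compound 1 to compound 2 (0.10 log units; within the scatter), in which the amine on that same chain carbon was exchanged and the number did not move beyond the scatter. Compound 3 also gives a number in the same range. On that ground no step beyond the scatter is expected for compound 4, and the expected step is a 1.1-fold lower number from compound 2 to compound 4 (0.04 log units; within the scatter). Compound 4 is estimated at 32000 nM in this assay, with a range from 15000 nM to 65000 nM.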

Compound 4, concentration for 50% growth inhibition: 15600 nM
Estimate against measurement, compound 4: 2.1-fold (0.31 log units) above, and the stated range covers the measured number.
By their numbers in this assay, from the lowest: compounds 4, 1, 3 and 2 (each within the scatter of the next, the first and the last beyond it).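

In this assay, among these compounds, the exchange of piperidin-1-yl for dimethylamino gives a 2.2-fold lower number from compound 2 to compound 4 (0.35 log units; beyond the scatter) and is the first step at this position to lie beyond the scatter, though only modestly. With a 1.8-fold lower number from compound 1 to compound 4 (0.25 log units; within the scatter) as the step from diethylamino to dimethylamino, the number stays within the scatter, so at this position dimethylamino can be told apart from piperidin-1-yl but not from diethylamino. Nothing measured here explains why the number moves with the first exchange and not the second.

The compounds shown leave open whether the step goes with the loss of the ring or with the lower count of heavy atoms. A morpholin-4-yl ring or a plain amino group on the same saturated chain carbon would test the reach of this change.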